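The source may hold more compounds than are shown below. What is called first, only, known or untested is meant among the compounds shown, and "the series" means these compounds.

Of the compounds shown here, three of one shared core have been tested in an assay on CHO cells for displacement of a labelled ligand from adenosine receptor A1 (Homo sapiens), read by scintillation counting, with a stated time of 60 min, tested at 10 uM; a higher number here means more inhibition at the concentration tested (going by the name of the read-out), a lower number less inhibition. Compound 1, `COCCNC(=O)c1cc2cccc(OC)c2oc1=N`, reaches the upper limit of this assay, giving > 70%. That figure is a limit of the measurement and not a number, so the true extent of its effect is only known to lie beyond it. Compound 2, `COc1cccc2cc(C(=O)NCC(=O)O)c(=O)oc12`, gives 27% in this assay, and compound 3, `N=c1oc2ccc(Br)cc2cc1C(=O)NC1CCCCC1`, gives 5%. Compound 1 therefore sits at the top of what has been recorded so far, with its value on the line (the limit of > 70% in this assay, at which 1 of the 3 values shown sits), while compound 2 and compound 3 sit well beneath it.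

The next compound to be examined is compound 4, `COc1cccc2cc(C(=O)NC3CCCCC3)c(=N)oc12`. It keeps the core of compound 1 and changes only the group on the amide nitrogen: cyclohexyl in place of 2-methoxyethyl on an amide-type nitrogen. Within the data shown here, no pair of measured compounds differs in exactly this way, so the size of the step can only be guessed. Compound 3 also carries cyclohexylamino on its core and gives a low value, which suggests the change may cost something. The step from compound 1 to compound 4 is expected to be a loss, a number at least 30 percentage points lower from compound 1 to compound 4 (beyond the scatter). Compound 4 is estimated to give around 40% in this assay, within a wide range from 5% to 75%.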

Compound 4, a percentage reported as inhibition, at one concentration (the size of the read-out at that concentration, not a potency): 40%
Compound 4: the middle estimate sits on the measured number at the digits printed, within the range that was stated.
By their numbers in this assay, from the lowest: compound 3; then compound 2; then compound 4. At a limit, above all of these: compound 1.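

Among these compounds, changing the group on the amide-type nitrogen while leaving the rest of the core of compound 1 untouched gives the first direct reading of this position: in this assay, cyclohexyl in place of 2-methoxyethyl gives a number at least 30 percentage points lower from compound 1 to compound 4 (beyond the scatter). The effect is reduced but not abolished, as compound 4 still gives 40%, so a group with one six-membered ring of carbon only and no hydrogen-bond acceptor can still be accommodated at this position. The full size of the loss stays unknown because compound 1 stands at a limit of the assay and not at a number: the limit of > 70% in this assay, at which 1 of the 4 values shown sits.

This single change replaces an open chain with a ring, alters the number of heavy atoms and removes the chain's oxygen all at once, and the compounds shown leave open which of these differences matters. An unbranched hexyl chain on the same nitrogen would test the ring separately from the oxygen, and a tetrahydropyranyl ring would test the oxygen while keeping a ring.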